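Catechol vinyl sulfones: shortening the sulfonyl chain

The source may hold more compounds than are shown below. What is called first, only, known or untested is meant among the compounds shown, and "the series" means these compounds.

The compounds share one core and differ only in the saturated chain on the sulfonyl sulfur. Compound 1 `CCCCCCCS(=O)(=O)/C=C/c1ccc(O)c(O)c1` gives 7100 nM in a functional assay, read by fluorescence and spectrophotometry, with a stated time of 1 h; a lower number here means that less compound is needed, a higher number that more compound is needed for the effect. Compound 2 `CCCCCCCCS(=O)(=O)/C=C/c1ccc(O)c(O)c1` gives 6400 nM and compound 3 `C=CCCCCCCS(=O)(=O)/C=C/c1ccc(O)c(O)c1` gives 6400 nM in this assay. On these numbers compound 3 stands level with compound 2, the two together the lowest of the three, and the step of a 1.1-fold lower number from compound 1 to compound 3 (0.05 log units; within the scatter) lies within the scatter; the steps of a 1.1-fold lower number from compound 1 to compound 2 (0.05 log units; within the scatter) and no change at the digits printed from compound 2 to compound 3 (within the scatter) likewise lie within the scatter. Each measured step alters a saturated chain carbon six or seven bonds along the chain from the sulfonyl sulfur, and none moves the read-out beyond the scatter.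

Compound 4 `CCCCCS(=O)(=O)/C=C/c1ccc(O)c(O)c1` is not yet measured. Its change from compound 3 is hydrogen in place of allyl on a saturated chain carbon, five bonds along the chain from a sulfonyl sulfur. The three measured steps bear on it, since all of them also vary the chain on the sulfonyl sulfur, and each was within the scatter; the present change removes more of the chain than any of them, so the expectation is less secure, but the numbers give no direction. The step to compound 4 is therefore expected to be a 1.1-fold higher number from compound 3 to compound 4 (0.04 log units; within the scatter), within the scatter. Compound 4 is estimated at 7000 nM, with a range from 3500 nM to 14000 nM in this assay.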

Compound 4, half-maximal effective concentration: 8100 nM
The estimate for compound 4 lay 1.2-fold (0.06 log units) below the measured number; the range from low to high includes it.
By their numbers in this assay, from the lowest: compounds 2, 3, 1 and 4 (each within the scatter of the next).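

In this assay, hydrogen in place of allyl on a saturated chain carbon, five bonds along the chain from a sulfonyl sulfur, gives a step that stays within the scatter (a 1.3-fold higher number from compound 3 to compound 4 (0.10 log units; within the scatter)), so the double bond and the chain end can go together without a read-out change that can be told from the scatter. The saturated comparisons agree, with hydrogen in place of propyl (a 1.3-fold higher number from compound 2 to compound 4 (0.10 log units; within the scatter)) and hydrogen in place of ethyl (a 1.1-fold higher number from compound 1 to compound 4 (0.06 log units; within the scatter)), which extends the flat stretch from six or seven bonds along the chain to five. Nothing at hand offers an explanation for this flat read-out.

It remains open whether the chain matters at all in this assay, since a butyl, ethyl or methyl group on the sulfonyl sulfur lies outside the compounds shown. Going by these compounds, a longer chain, or an amine or carboxylic acid at the chain end, is equally open.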